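The compounds below may be only part of what the source reports. "The series", "measured", "known", "first", "only" and "open" are said of these compounds alone.

Measured in a functional assay on MCF7 cells (Homo sapiens) for cytotoxicity, read by CellTiter-Glo, with a stated time of 5 days; on this read-out lower numbers stand for stronger inhibition and higher numbers for weaker inhibition:
- Compound 1 `CC/C(=C(/c1ccc(/C=C/C(=O)O)cc1)c1ccc(NS(C)(=O)=O)cc1)c1ccccc1`: 2310 nM
- Compound 2 `CC/C(=C(/c1ccc(/C=C/C(=O)O)c(C)c1)c1ccc2[nH]ncc2c1)c1ccccc1`: 14 nM
- Compound 3 `CC/C(=C(/c1ccc(/C=C/C(=O)O)cc1)c1ccc2[nH]ncc2c1)c1ccccc1C#N`: 12 nM

Compound 3, at 12 nM, cannot be told apart from compound 2, at 14 nM, as the two values lie within the scatter of each other. Compound 1, at 2310 nM, stands well beyond the scatter on the weaker side of both.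

Compound 4 `CC/C(=C(/c1ccc(/C=C/C(=O)O)cc1)c1ccc2[nH]ncc2c1)c1ccc(C#N)cc1Cl` carries 2-chloro-4-cyanophenyl in place of the 2-cyanophenyl of compound 3, on a double-bonded chain carbon bound to a double-bonded chain carbon and a saturated chain carbon (2-chloro-4-cyanophenyl in place of 2-cyanophenyl on a double-bonded chain carbon bound to a double-bonded chain carbon and a saturated chain carbon). Among the measured compounds shown here, no pair of measured compounds differs in one place only, so the data offer no direct guide to this change. In this assay, the expectation is therefore a small move toward a higher number, probably none beyond the scatter. The estimated change is a 1.3-fold higher number from compound 3 to compound 4 (0.10 log units; within the scatter). For compound 4, the expected value is 15 nM, with an estimated range of 5 nM to 60 nM.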

Compound 4, half-maximal inhibitory concentration: 4 nM
For compound 4 the middle estimate is 3.8-fold (0.57 log units) above the measured one; the whole stated range lies above it.
By their numbers in this assay, from the lowest: compound 4; then compounds 3 and 2 (each within the scatter of the next); then compound 1.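

In this assay, among the compounds shown here, the exchange of 2-cyanophenyl for 2-chloro-4-cyanophenyl on a double-bonded chain carbon bound to a double-bonded chain carbon and a saturated chain carbon gives a 3.0-fold lower number from compound 3 to compound 4 (0.48 log units; beyond the scatter) and so provides the first comparison of compounds that differ in one place. It shows that this position still responds to a change in its ring substituents, even from the low value of compound 3, and that the change goes toward stronger inhibition. No measurement at hand accounts for this step.

The change adds a chlorine and shifts the nitrile at once, so the compounds shown leave open which of the two carries the step. Also open, as far as these compounds go, is how 2-chlorophenyl or 4-cyanophenyl alone, or a ring bearing a methoxy group, would read at this position.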